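The compounds below may be only part of what the source reports. "The series", "measured", "known", "first", "only" and "open" are said of these compounds alone.

Working notes on the ester series. Compound 1 `C=C1C(=O)O[C@H]2CC3=C[C@H](C/C(C)=C/[C@@H](OC(=O)/C=C/c4cccc(OC)c4)[C@H]12)OC3=O` carries a 2-(3-methoxyphenyl)ethenyl group on the ester carbonyl carbon. In a functional assay on NCI-H460 cells (Homo sapiens) for cytotoxicity, read by MTT assay, with a stated time of 48 h (on this read-out higher numbers stand for weaker inhibition and lower numbers for stronger inhibition), compound 1 gives only a limit, > 10000 nM, (the limit of > 10000 nM in this assay, at which 1 of the 2 values shown sits). Compound 2 `C=C1C(=O)O[C@H]2CC3=C[C@H](C/C(C)=C/[C@@H](OC(=O)CCCCC)[C@H]12)OC3=O` has pentyl in that position, and in this assay compound 2 gives 5900 nM. Among the compounds with values here, the one measured step is an at least 1.6-fold lower number from compound 1 to compound 2 (0.22 log units; that floor lies within the scatter). Within the data shown here, compound 2 thus stands as the only compound with a number in this assay; the other value is a limit.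

Compound 3 `C=C1C(=O)O[C@H]2CC3=C[C@H](C/C(C)=C/[C@@H](OC(=O)/C=C/c4cccs4)[C@H]12)OC3=O` differs from compound 2 by 2-(thiophen-2-yl)ethenyl in place of pentyl on a carbonyl carbon. The step from compound 1 to compound 2 bears on this change in the reverse direction: moving from pentyl to an arylethenyl group on the carbonyl carbon is expected to move the number in this assay back toward the limit, a rise of a 1.5-fold higher number from compound 2 to compound 3 (0.18 log units; within the scatter), with a considerable chance that only a limit is returned. For compound 3 the value in this assay is estimated at 9000 nM, between 3500 nM and 25000 nM.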

Compound 3, half-maximal inhibitory concentration: 2900 nM
Estimate against measurement, compound 3: 3.1-fold (0.49 log units) above; the whole stated range lies above it.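

Within the data shown here, on the ester carbonyl carbon, an arylethenyl group is not tied to the weak end of this assay: 2-(thiophen-2-yl)ethenyl in place of pentyl gives a 2.0-fold lower number from compound 2 to compound 3 (0.31 log units; beyond the scatter), the first step at this position beyond the scatter. Between the two arylethenyl esters, thiophen-2-yl in place of 3-methoxyphenyl gives an at least 3.4-fold lower number from compound 1 to compound 3 (0.53 log units; beyond the scatter). That step is only a floor, as compound 1 gives a limit: the limit of > 10000 nM in this assay, at which 1 of the 3 values shown sits.

Going by these compounds, it remains open whether the difference between the two arylethenyl esters follows the thiophene ring or the methoxy group, which furan-2-yl or unsubstituted phenyl on the same ethenyl chain would help separate. Also open, on these data alone, are the part played by the ethenyl link, which a saturated 2-(thiophen-2-yl)ethyl group would address, and the reading of a longer chain in place of pentyl.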